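Compound 4: A Chlorophenyl for a Fluorobenzyl

The source may hold more compounds than are shown below. What is called first, only, known or untested is meant among the compounds shown, and "the series" means these compounds.

In an ADME assay on HeLa cells (Homo sapiens) for cytotoxicity, read by MTT assay (a higher number here means a weaker inhibitor, a lower number a stronger inhibitor), compound 3 `COc1ccc(C[C@H]2COC(=O)[C@@H]2Cc2ccc(OCc3cn(Cc4ccc(F)cc4)nn3)c(OC)c2)cc1OC` gives 198000 nM, within the scatter of both other measured compounds. Compound 1 `COc1ccc(C[C@H]2COC(=O)[C@@H]2Cc2ccc(OCc3cn(-c4ccc(Br)cc4)nn3)c(OC)c2)cc1OC` gives 128000 nM, and compound 2 `COc1ccc(C[C@H]2COC(=O)[C@@H]2Cc2ccc(OCC(=O)N3CCCCC3)c(OC)c2)cc1OC` gives 293000 nM. Compound 4 `COc1ccc(C[C@H]2COC(=O)[C@@H]2Cc2ccc(OCc3cn(-c4cccc(Cl)c4)nn3)c(OC)c2)cc1OC` carries 3-chlorophenyl in place of 4-fluorobenzyl on an aromatic nitrogen. The nearest guide is the swap of 4-bromophenyl for 4-fluorobenzyl on that nitrogen: a 1.5-fold higher number from compound 1 to compound 3 (0.19 log units; within the scatter), within the scatter. The modest step of a 2.3-fold higher number from compound 1 to compound 2 (0.36 log units; beyond the scatter) exchanges the whole group, so it bears less on this change. In this assay a small move toward a lower number, not beyond the scatter, is expected: a 1.3-fold lower number from compound 3 to compound 4 (0.12 log units; within the scatter). The estimate for compound 4 is 150000 nM, with an expected range of 80000 nM to 280000 nM.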

Compound 4, half-maximal inhibitory concentration: 493000 nM
Compound 4: the middle estimate sits 3.3-fold (0.52 log units) below what was measured; measured number above the stated range.
By their numbers in this assay, from the lowest: compounds 1, 3, 2 and 4 (each within the scatter of the next, the first and the last beyond it).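

Until now, changes on this aromatic nitrogen had stayed within the scatter, but in this assay 3-chlorophenyl in place of 4-fluorobenzyl moves beyond it, a 2.5-fold higher number from compound 3 to compound 4 (0.40 log units; beyond the scatter). The same holds for 3-chlorophenyl in place of 4-bromophenyl, a 3.9-fold higher number from compound 1 to compound 4 (0.59 log units; beyond the scatter), while exchanging the whole group leaves compound 4 within the scatter of compound 2, a 1.7-fold higher number from compound 2 to compound 4 (0.23 log units; within the scatter). No measured evidence accounts for this shift.

Against compound 1, compound 4 differs in both the halogen and where it sits on the phenyl ring, and these two changes remain unseparated. A 4-chlorophenyl or 3-bromophenyl group on this nitrogen would tell them apart.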